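A few compounds are considered here, and "the series" means these few. Any claim that something is new, unique, unknown or untested is made for them only; others in the source may bear on it.

Measured so far in a functional assay on HT-29 cells (Homo sapiens) for inhibition, read by MTT assay, with a stated time of 120 h; on this read-out higher numbers stand for weaker inhibition and lower numbers for stronger inhibition:

- compound 1 `C/C(=C\c1ccc(NC(=O)Nc2ccc(Cl)c(C(F)(F)F)c2)cc1)C(=O)NC(C)c1ccccc1`: > 50000 nM
- compound 2 `CC1CN(C(=O)c2ccc(-c3ccc(NC(=O)Nc4ccc(Cl)c(C(F)(F)F)c4)cc3)cc2)CC(C)O1`: 2050 nM
- compound 3 `O=C(/C=C/c1ccc(NC(=O)Nc2ccc(Cl)c(C(F)(F)F)c2)cc1)NC1CCC1`: 4430 nM

All three share the same diaryl urea core and differ in what hangs off the far side of it. Compound 1 reaches only the limit of this assay, > 50000 nM, so no number is known for it. Compound 2 gives 2050 nM, while compound 3 gives 4430 nM. Of the two actual numbers, compound 3 has the higher one, and its gap to compound 2 lies beyond the usual scatter, so compound 3 is the weaker of those two.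

Compound 4 `CNC(=O)/C=C/c1ccc(NC(=O)Nc2ccc(Cl)c(C(F)(F)F)c2)cc1` has not yet been measured in this assay. It differs from compound 3 in one place: methyl in place of cyclobutyl on an amide-type nitrogen. Among the measured compounds shown here, no two measured compounds differ by a single change, so no measured step exists to lean on. With compound 3 at 4430 nM as the starting point, the step of a 1.8-fold higher number from compound 3 to compound 4 (0.26 log units; within the scatter) is expected to be small, leaning toward weaker inhibition rather than stronger. Compound 4 is therefore estimated at 8000 nM, within a range from 2500 nM to 30000 nM.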

Compound 4, half-maximal inhibitory concentration: 11700 nM
For compound 4 the middle estimate is 1.5-fold (0.17 log units) below the measured one; the range from low to high includes it.
By their numbers in this assay, from the lowest: compound 2; then compound 3; then compound 4. At a limit, above all of these: compound 1.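

This is the only step shown in which a single group changes: in this assay, putting methyl in place of cyclobutyl on the amide-type nitrogen weakens inhibition (a 2.6-fold higher number from compound 3 to compound 4 (0.42 log units; beyond the scatter)). The position is therefore not indifferent to what it carries, and within this pair the group without a ring gives the weaker inhibition, though the step is modest. Nothing shown explains why the number rises.

With only these two groups to compare at this nitrogen, it remains unclear whether the ring itself or simply the number of carbons matters. Also open, on these data alone, is how a cyclopentyl ring, an isopropyl group or a longer chain ending in an amine would read at this position.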